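This account rests on a few compounds, and the source may have more. Where it says the series, first, only, none or still open, it means among the compounds named here.

- compound 1 `CCNc1cc(OC)c(C(=O)NC2CCN(Cc3ccccc3)C2)cc1Cl`: 0.1 mg/kg
- compound 2 `COc1cc(N2CCCC2)c(Cl)cc1C(=O)NC1CCN(Cc2ccccc2)C1`: 0.6 mg/kg

In a functional assay on the whole organism with Rattus norvegicus as the target (on this read-out higher numbers stand for an effect only at larger amounts of compound and lower numbers for an effect already at smaller amounts), compound 2 gives 0.6 mg/kg, the higher of the two numbers, so it needs the larger dose of the pair. Compound 3 `COc1cc(NC(C)=O)c(Cl)cc1C(=O)NC1CCN(Cc2ccccc2)C1` keeps the rest of compound 2 and changes one group: acetamido in place of pyrrolidin-1-yl on an aromatic carbon, ortho to a chloro group (acetamido in place of pyrrolidin-1-yl on an aromatic carbon).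

Among the compounds with values here, only one measured step bears on this change. It sits on the same aromatic carbon and swaps ethylamino for pyrrolidin-1-yl, giving a 6.0-fold higher number from compound 1 to compound 2 (0.78 log units; beyond the scatter). That step shows that this assay responds to the group at this place, and its size is modest. Within the data shown here, no measured compound carries acetamido, so the direction remains a judgement. A further rise of similar size is the most likely outcome, although the range must stay wide with so little data. The expected step is a 3.3-fold higher number from compound 2 to compound 3 (0.52 log units; beyond the scatter). For compound 3 the estimated value is 2 mg/kg, with an expected range from 0.5 mg/kg to 10 mg/kg.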

Compound 3, dose for half-maximal effect: 1.8 mg/kg
Compound 3: the middle estimate sits 1.1-fold (0.05 log units) above what was measured; the measured number falls inside the stated range.
By their numbers in this assay, from the lowest: compound 1; then compound 2; then compound 3.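

In this assay the swap of pyrrolidin-1-yl for acetamido gives a 3.0-fold higher number from compound 2 to compound 3 (0.48 log units; beyond the scatter), so this aromatic carbon, ortho to a chloro group, now has three groups on it, and each one gives a clearly different dose. Within the data shown here, the nitrogen on the ring can be compared directly, since acetyl in place of ethyl on it gives an 18-fold higher number from compound 1 to compound 3 (1.26 log units; beyond the scatter), the largest step so far, and the two groups without a ring, ethylamino and acetamido, lie at opposite ends of the series with the ring-bearing pyrrolidin-1-yl in the middle, so the presence of a ring alone does not sort these three numbers. Nothing available explains why the dose moves in this way with these groups.

On these data alone, it remains open whether an unsubstituted amino group or a longer chain on the nitrogen, such as propylamino, would fall near compound 1 or further up the series. Also open, as far as these compounds go, is whether the same order of the three groups would hold with a bromo group in place of the chloro group on the shared core.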